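Moving the nitro group around the ring: compound 2 to compound 4

The source may report more compounds than this note shows. Statements on the series, on what has been measured and on what is new or still open speak of the compounds shown alone.

Of the compounds shown here, three have been measured in a functional assay on HL-60 cells (Homo sapiens) for cytotoxicity, read by WST assay, with a stated time of 48 h; on this read-out higher numbers stand for weaker inhibition and lower numbers for stronger inhibition. Compound 1 `COc1cccc(/C=C/C[C@H]2C[C@@H]([C@@H](O)c3ccccc3)CO[C@@H]2c2ccccc2)c1` gives 9620 nM. Compound 2 `O=[N+]([O-])c1cccc(/C=C/C[C@H]2C[C@@H]([C@@H](O)c3ccccc3)CO[C@@H]2c2ccccc2)c1` gives 6350 nM. Compound 3 `COc1ccc(/C=C/C[C@H]2C[C@@H]([C@@H](O)c3ccc(OC)c(OC)c3)CO[C@@H]2c2ccc(OC)c(OC)c2)cc1OC` gives 34700 nM. Among these three numbers compound 2 has the lowest, though the value of compound 1 lies within the usual scatter of it, while the value of compound 3 lies beyond it. Among the measured compounds shown here, the only single change measured so far, a 1.5-fold lower number from compound 1 to compound 2 (0.18 log units; within the scatter), stayed within the scatter.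

Compound 4 `O=[N+]([O-])c1ccccc1/C=C/C[C@H]1C[C@@H]([C@@H](O)c2ccccc2)CO[C@@H]1c1ccccc1` differs from compound 2 in one place: 2-nitrophenyl in place of 3-nitrophenyl on a double-bonded chain carbon bound to a double-bonded chain carbon. For the measured compounds named here, no measured step moves a nitro group from one ring position to another, so there is nothing that points to a change beyond the scatter. The estimated step is therefore a 1.0-fold higher number from compound 2 to compound 4 (0.01 log units; within the scatter). Compound 4 is expected to give 6500 nM in this assay, within a range from 3000 nM to 14000 nM.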

Compound 4, half-maximal inhibitory concentration: 7250 nM
Compound 4: the middle estimate sits 1.1-fold (0.05 log units) below what was measured; measured number inside the range.
By their numbers in this assay, from the lowest: compounds 2, 4 and 1 (each within the scatter of the next); then compound 3.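

In this assay the swap to 2-nitrophenyl from 3-nitrophenyl on this chain carbon gives a 1.1-fold higher number from compound 2 to compound 4 (0.06 log units; within the scatter) and so shows that moving the nitro group around this ring makes no readable difference here. The swap to 2-nitrophenyl from 3-methoxyphenyl at the same place gives a 1.3-fold lower number from compound 1 to compound 4 (0.12 log units; within the scatter) and likewise stays too small to separate from repeat-measurement noise. No measured evidence is available to explain these results. From the compounds shown here alone, whether 4-nitrophenyl, or an amine or a carboxylic acid on this ring, would move the number beyond the scatter remains open.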